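Aryl replacement at the shared core: outlook for compound 4

The source may hold more compounds than are shown below. What is called first, only, known or untested is meant among the compounds shown, and "the series" means these compounds.

Measured so far in a functional assay on aorta (Rattus norvegicus) for inhibition; on this read-out lower numbers stand for smaller maximal responses and higher numbers for larger maximal responses:

compound 1 `CCOC(=O)c1c(C)[nH]c(=O)c(C#N)c1-c1ccco1`: 93%
compound 2 `CCOC(=O)c1c(C)[nH]c(=O)c(C#N)c1-c1ccc([N+](=O)[O-])cc1[N+](=O)[O-]`: 99%
compound 3 `CCOC(=O)c1c(C)[nH]c(=O)c(C#N)c1-c1cccs1`: 99%

Compound 3 stands level with compound 2 at the digits shown, and these two together give the highest of the three numbers. The nearest neighbour is compound 2, with no change at the digits shown, and the furthest is compound 1. Within the data shown here, the single measured step at this position, a number 6 percentage points higher from compound 1 to compound 3 (within the scatter), stays within the scatter.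

Compound 4 `CCOC(=O)c1c(C)[nH]c(=O)c(C#N)c1-c1cccc(Cl)c1` is not yet measured. The change from compound 3 is 3-chlorophenyl in place of thiophen-2-yl on an aromatic carbon. The step that bears on it is a number 6 percentage points higher from compound 1 to compound 3 (within the scatter), since it also exchanges the ring on that aromatic carbon, and it brought nothing beyond the scatter. Compound 2 carries a six-membered carbon-only ring at the same position, and compound 2 gives 99%, the same number at the digits shown as compound 3. Three aromatic rings of two different sizes thus all sit at the top of the range, so in this assay no step beyond the scatter is expected for this exchange, in either direction.

The expected step from compound 3 to compound 4 is a number 2 percentage points lower from compound 3 to compound 4 (within the scatter), a change within the scatter. For compound 4 the estimate in this assay is 97%, with a range from 85% to 105%.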

Compound 4, largest response reached (reported as efficacy), in percent of the reference or control that the assay uses: 99%
Beside the measured number, compound 4's estimate is 2 percentage points below it; the measured number falls inside the stated range.
By their numbers in this assay, from the lowest: compounds 1, 2, 3 and 4 (each within the scatter of the next).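

In this assay, the position on the aromatic carbon opposite the ring nitrogen accepts 3-chlorophenyl with no change at the digits printed from compound 3 to compound 4 (within the scatter) and with a number 6 percentage points higher from compound 1 to compound 4 (within the scatter), so this exchange leaves the number within the scatter against either five-membered ring. The earlier compounds shown here offered a six-membered ring of carbon only solely with two nitro groups, whereas compound 2 gives 99% and compound 4, with a single chlorine, gives 99%, so the two substituted phenyl rings print the same value. Across the four compounds the read-out therefore shows no step beyond the scatter at this position, and no measurement available here bears on why the values remain this close.

With all four aromatic rings lying within the scatter of one another, the compounds shown do not reveal what would lower the number at this position, for instance a saturated cyclohexyl ring in place of the aromatic ring, or a phenyl ring carrying an amine or a carboxylic acid. Also open, on these data alone, is whether a longer chain in place of the ethoxycarbonyl group on the shared core would move the read-out.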